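The source may report more compounds than this note shows. Statements on the series, on what has been measured and on what is new or still open speak of the compounds shown alone.

Among the measured compounds shown here, of the two compounds measured so far in a functional assay (muscle tissue) with Cavia porcellus as the target (on this read-out higher numbers stand for an effect only at larger amounts of compound and lower numbers for an effect already at smaller amounts), compound 1 `COC(=O)C1=C(C)N=C(C)/C(=C(\O)OC)C1c1cccc(O)c1` has the higher number: compound 1 gives 1000 nM. For the measured compounds named here, the only comparison is compound 2 `CCc1ccccc1C1C(C(=O)OC)=C(C)N=C(C)/C1=C(\O)OC`, and compound 2 gives 6.46 nM. This is a 150-fold lower number from compound 1 to compound 2 (2.19 log units; beyond the scatter), a large step well beyond the usual scatter.

Compound 3 `COC(=O)C1=C(C)N=C(C)/C(=C(\O)OC)C1c1cccc(C(F)(F)F)c1` keeps the core of compound 1 and changes one group: trifluoromethyl in place of hydroxy on an aromatic carbon. In short, trifluoromethyl stands in place of hydroxy on an aromatic carbon, meta to a large group.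

Going by the values given here, no measured step makes exactly this exchange, so the evidence is thin. Among the compounds with values here, the nearest guide is the single step of a 150-fold lower number from compound 1 to compound 2 (2.19 log units; beyond the scatter), which also takes the hydroxy away, although a different group enters there. On that basis, a clear move to a lower number is expected in this assay, beyond the scatter, and probably somewhat smaller than that single step. The expected change is a 67-fold lower number from compound 1 to compound 3 (1.82 log units; beyond the scatter). For compound 3 the estimated value is 15 nM, with an expected range from 4 nM to 80 nM.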

Compound 3, half-maximal effective concentration: 74.1 nM
Compound 3: middle estimate off by 4.9-fold (0.69 log units), on the low side, and the stated range covers the measured number.
By their numbers in this assay, from the lowest: compound 2; then compound 3; then compound 1.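

In this assay, keeping the aromatic ring position fixed and exchanging only the group there gives a 13-fold lower number from compound 1 to compound 3 (1.13 log units; beyond the scatter), so a change at this one place is enough to shift the read-out clearly. The earlier step replaced 3-hydroxyphenyl with 2-ethylphenyl, which changed both the group and where it sits on the ring, whereas here the place stays meta to a large group and only the group differs. The exchange also removes the hydrogen-bond donor and acceptor counted for hydroxy and brings in a larger group with neither, but no available measurement explains why the number falls.

Among the compounds shown here, with only this one exchange at this place, it remains open whether the lower number comes from losing hydroxy or from gaining trifluoromethyl. As far as these compounds go, a methoxy group, an amine or a carboxylic acid on the same aromatic carbon would help separate these two readings, and it is also open whether trifluoromethyl would give a similar step elsewhere on the ring.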